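Swapping the Aryl Group on a Noncytotoxic Compound

The source may report more compounds than this note shows. Statements on the series, on what has been measured and on what is new or still open speak of the compounds shown alone.

- compound 1 `N#Cc1c(-c2ccccc2Cl)c(C#N)c(=O)n(/N=C/c2cn(-c3ccccc3)nc2-c2ccccc2)c1N`: > 200 ug/mL, a limit
- compound 2 `N#Cc1c(-c2cccc(Cl)c2)c(C#N)c(=O)n(/N=C/c2cn(-c3ccccc3)nc2-c2ccccc2)c1N`: > 200 ug/mL, a limit

Both results come from an ADME assay on HeLa cells (Homo sapiens) for cytotoxicity, read by MTT assay; on this read-out higher numbers stand for weaker inhibition and lower numbers for stronger inhibition. Compound 1 stands only at a limit, > 200 ug/mL, so it has no exact number. Compound 3 `N#Cc1c(-c2ccc(F)cc2)c(C#N)c(=O)n(/N=C/c2cn(-c3ccccc3)nc2-c2ccccc2)c1N` carries one change from compound 1: 4-fluorophenyl in place of 2-chlorophenyl on an aromatic carbon. The 4-fluorophenyl group takes the place of the 2-chlorophenyl group, on the aromatic carbon opposite the ring nitrogen. Among the compounds with values here, one measured step bears on this swap: a step that the two limits leave unreadable from compound 1 to compound 2. It also changes the aryl group, but its size cannot be read. Both measured compounds share one result: the limit of > 200 ug/mL in this assay, at which 2 of the 2 values shown sit. Within the data shown here, with no sized step to draw on, no step beyond the scatter is expected in this assay, and no direction can be given. The expected step is a number no higher from compound 1 to compound 3 (the limit leaves the size open). Compound 3 is expected to give about 200 ug/mL, with an estimated range from 90 ug/mL to 400 ug/mL.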

Compound 3, half-maximal inhibitory concentration: > 200 ug/mL
Compound 3 was reported as a limit (the forecaster's own chance of this, stated with the estimate: 75%); the middle value sits exactly at the limit.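

No step can be read among compound 1, compound 2 and compound 3, as each result is a limit and not a number: the limit of > 200 ug/mL in this assay, at which 3 of the 3 values shown sit.

The compounds shown leave open whether any aryl group on the shared core would give an exact value in this assay.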